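Removing the fluorines: from compound 1 to compound 4

A few compounds are considered here, and "the series" means these few. Any claim that something is new, unique, unknown or untested is made for them only; others in the source may bear on it.

Compound 1 `O=C1c2ccc(OCc3cccc(-c4ccc(C(F)(F)F)cc4F)c3)cc2CN1C1CCCC1`: > 5000 nM 
Compound 2 `O=C(O)c1cc(-c2cccc(-c3ccc4c(c3)CN(C3CCCC3)C4=O)c2)ccc1Cl`: 20 nM 
Compound 3 `CC(C)CCn1sc2cc(OCc3cccc(-c4ccc(Cl)c(C(=O)O)c4)c3)ccc2c1=O`: 650 nM 

Three compounds were measured in an assay on HEK293 cells for positive allosteric modulation of metabotropic glutamate receptor 2 (Rattus norvegicus), read by thallium flux; a lower number here means that less compound is needed, a higher number that more compound is needed for the effect. Compound 1 gives only a limit, > 5000 nM, which means that no number was reached for it within the range of this assay; this is the limit of > 5000 nM in this assay, at which 1 of the 3 values shown sits. Compound 2, which carries a chlorine and a carboxylic acid on its outer ring, gives 20 nM in this assay. Compound 3 gives 650 nM in this assay.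

Compound 4 `O=C1c2ccc(OCc3cccc(-c4ccccc4)c3)cc2CN1C1CCCC1` is the new compound. It differs from compound 1 in one place: phenyl in place of 2-fluoro-4-(trifluoromethyl)phenyl on an aromatic carbon. The core of compound 1 and its cyclopentyl group stay the same.

Within the data shown here, no step between two measured compounds was taken here, so the expectation for compound 4 rests on compound 1 alone, which stands at a limit in this assay. With the fluorines gone and no acid added, compound 4 is expected to stay at that limit as well; the expected step that the limit leaves unreadable from compound 1 to compound 4 is none beyond the scatter. Compound 4 is thus estimated at 8000 nM, within 3000 nM to 30000 nM.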

Compound 4, half-maximal effective concentration: > 5000 nM
Compound 4 ended at the assay's limit; the forecaster's own chance of this, stated with the estimate: 75%; the middle value is on the limit's open side.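

Compound 1 and compound 4 both end at a limit in this assay and not at a number, so no step can be read between them: the limit of > 5000 nM in this assay, at which 2 of the 4 values shown sit.

The compounds shown leave open whether phenyl and 2-fluoro-4-(trifluoromethyl)phenyl differ at all in their effect on this core.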